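Phenyl for tert-butyl on the core of compound 2

The source may report more compounds than this note shows. Statements on the series, on what has been measured and on what is new or still open speak of the compounds shown alone.

Compound 2 `CC(C)(C)c1ccc(CNCCNS(=O)(=O)c2cc(C(F)(F)F)cc(C(F)(F)F)c2)cc1` stands highest of the three measured compounds in a toxicity assay on MCF-10A cells (Homo sapiens) for inhibition, read by MTT assay, with a stated time of 72 h (on this read-out lower numbers stand for stronger inhibition of growth and higher numbers for weaker inhibition of growth), where compound 2 gives 14000 nM. Compound 1 `O=S(=O)(NCCCNCc1cccc2ccccc12)c1cc(C(F)(F)F)cc(C(F)(F)F)c1` gives 3200 nM and compound 3 `O=S(=O)(NCCCNCc1ccc(Cl)cc1)c1cc(C(F)(F)F)cc(C(F)(F)F)c1` gives 2300 nM; both sit beyond the scatter below compound 2, but compound 1 and compound 3 share a core that differs from the core of compound 2, so their gap to compound 2 is not a single change.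

Compound 4 `O=S(=O)(NCCNCc1ccc(-c2ccccc2)cc1)c1cc(C(F)(F)F)cc(C(F)(F)F)c1` keeps the core of compound 2 and carries phenyl in place of tert-butyl on an aromatic carbon. Among the measured compounds shown here, the only measured step, a 1.4-fold lower number from compound 1 to compound 3 (0.14 log units; within the scatter), exchanges one aryl group for another on the other core and lies within the scatter; it does not involve a group on an aromatic carbon and bears on the present change only loosely. For the measured compounds named here, no measured pair shows how phenyl in place of tert-butyl moves this assay. The expectation is therefore a step from compound 2 to compound 4 of no size beyond the scatter, a 1.4-fold lower number from compound 2 to compound 4 (0.15 log units; within the scatter), with a wide range. Compound 4 is estimated at 10000 nM, between 3500 nM and 30000 nM.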

Compound 4, concentration for 50% growth inhibition: 3300 nM
Beside the measured number, compound 4's estimate is 3.0-fold (0.48 log units) above it; the whole stated range lies above it.
By their numbers in this assay, from the lowest: compounds 3, 1 and 4 (each within the scatter of the next); then compound 2.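

On the core of compound 2, the group on this aromatic carbon, para to a large group, clearly matters in this assay: a 4.2-fold lower number from compound 2 to compound 4 (0.63 log units; beyond the scatter). Among the compounds shown here, this is the first measured step at this position and the first on this core, so the high number of compound 2 belongs to that compound with its tert-butyl and not to the core as such. No measurement at hand bears on what lies behind this step.

The compounds shown leave open whether a non-aromatic ring such as cyclohexyl or a smaller group such as methoxy on the same aromatic carbon would give a step like that of phenyl. They also leave open whether phenyl in place of tert-butyl moves the number to a similar extent on the core of compound 1.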